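The source may hold more compounds than are shown below. What is called first, only, known or untested is meant among the compounds shown, and "the series" means these compounds.

Measured so far:
- compound 1, `CCOc1cc(C(C)(C)C)ccc1C1=NC(c2ccc(Cl)cc2)C(c2ccc(Cl)cc2)N1C(=O)N1CCN(Cc2ccc(C(=O)NO)cc2)CC1`, 3000 nM
- compound 2, `CCOc1cc(C(C)(C)C)ccc1C1=NC(c2ccc(Cl)cc2)C(c2ccc(Cl)cc2)N1C(=O)NCCCCCCCC(=O)NO`, 9060 nM
- compound 3, `CCOc1cc(C(C)(C)C)ccc1C1=NC(c2ccc(Cl)cc2)C(c2ccc(Cl)cc2)N1C(=O)NCCCCCC(=O)Nc1ccccc1N`, 19100 nM

These three compounds share a core and were tested in a functional assay on NCI-H1299 cells (Homo sapiens) for antiproliferative activity, read by CCK-8 assay, with a stated time of 72 h; on this read-out lower numbers stand for stronger inhibition and higher numbers for weaker inhibition. Compound 1 gives the lowest number of the three; compound 2 sits a good distance above it, and compound 3 further still. Going by the values given here, the one single-point change among them, a 2.1-fold higher number from compound 2 to compound 3 (0.32 log units; beyond the scatter), swaps the group at the end of a flexible chain and weakens activity modestly.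

Compound 4, `CCOc1cc(C(C)(C)C)ccc1C1=NC(c2ccc(Cl)cc2)C(c2ccc(Cl)cc2)N1C(=O)N1CCN(CCCCC(=O)NO)CC1`, has not yet been measured. It differs from compound 1 in one place: 3-(hydroxycarbamoyl)propyl in place of 4-(hydroxycarbamoyl)phenyl on a saturated chain carbon bound to an amine nitrogen in a ring. Among the compounds with values here, no measured step matches this change directly. What the numbers show is that compound 1, where the hydroxamic acid sits on an aromatic ring linked through the ring nitrogen, reads stronger than compound 2, where the hydroxamic acid sits at the end of a long saturated chain; but these two differ in more than one place, so nothing firm follows. Given that, compound 4 is expected to land somewhat weaker than compound 1, with the step of a 1.7-fold higher number from compound 1 to compound 4 (0.22 log units; within the scatter) modest in size. The estimated value for compound 4 in this assay is 5000 nM, within a range of 1500 nM to 16000 nM.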

Compound 4, half-maximal inhibitory concentration: 12900 nM
Beside the measured number, compound 4's estimate is 2.6-fold (0.41 log units) below it; low and high end bracket the measured number.
By their numbers in this assay, from the lowest: compound 1; then compounds 2, 4 and 3 (each within the scatter of the next, the first and the last beyond it).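

In this assay, putting 3-(hydroxycarbamoyl)propyl in place of 4-(hydroxycarbamoyl)phenyl gives a 4.3-fold higher number from compound 1 to compound 4 (0.63 log units; beyond the scatter), so the group on this saturated chain carbon bound to an amine nitrogen in a ring does change the read-out. This is the first comparison shown that alters this position alone: the hydroxycarbamoyl end group stays, and the form carrying a six-membered aromatic ring of carbon only reads stronger than the form with no ring. The pair cannot separate the loss of the ring from the change in the size of the group, and no measurement available here explains the difference.

The compounds shown leave open whether a longer saturated chain ending in hydroxycarbamoyl, such as 5-(hydroxycarbamoyl)pentyl, would bring the number closer to that of compound 1, or whether a pyridine ring could stand in for the phenyl ring. Also open, going by these compounds, is how the (2-aminophenyl)carbamoyl end group of compound 3 would read when attached through this same position.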